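The compounds below may be only part of what the source reports. "The series", "measured", "known", "first", "only" and "open" are said of these compounds alone.

Going by the values given here, compound 2 `O=C(Nc1ccc(S(=O)(=O)Nc2ccccc2)cc1)c1ccc(Cl)cc1Cl` is the one compound with a measured number in a functional assay on HEK293 cells for agonist activity at probable G-protein coupled receptor 27 (Homo sapiens), read by a luciferase reporter and beta-arrestin recruitment, with a stated time of 10 min (on this read-out higher numbers stand for an effect only at larger amounts of compound and lower numbers for an effect already at smaller amounts), where compound 2 gives 457 nM. Compound 1 `O=C(NS(=O)(=O)c1ccc(NC(=O)c2ccc(Cl)cc2Cl)cc1)c1ccccc1` is recorded there only as a limit of the assay, > 100000 nM (the limit of > 100000 nM in this assay, at which 1 of the 2 values shown sits). Among the compounds with values here, the single measured step, an at least 210-fold lower number from compound 1 to compound 2 (2.34 log units; beyond the scatter), therefore runs from a limit to a number and concerns the group on the sulfonamide nitrogen. Compound 3 `O=C(Nc1ccc(S(=O)(=O)Nc2ccc(Cl)cc2)cc1)c1ccc(Cl)cc1Cl` differs from compound 2 in another place: chloro in place of hydrogen on an aromatic carbon. Within the data shown here, no measured step touches this position, so nothing in the data points to a change beyond the usual scatter in either direction. The expected step for compound 3 is a 1.1-fold lower number from compound 2 to compound 3 (0.06 log units; within the scatter), within the scatter of this assay. The estimate for compound 3 in this assay is 400 nM, with a range from 130 nM to 1500 nM.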

Compound 3, half-maximal effective concentration: > 100000 nM
Compound 3: a limit, no number; the forecaster's own chance of this, stated with the estimate: 10%; at least 250-fold (2.39 log units) between middle value and limit.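

In this assay the phenyl group on the sulfonamide nitrogen proves sensitive to a single added atom: chloro in place of hydrogen on an aromatic carbon, para to a large group, gives an at least 210-fold higher number from compound 2 to compound 3 (2.34 log units; beyond the scatter). The earlier step replaced the whole group on that nitrogen, whereas this one shows that a change of one heavy atom within the phenyl group is enough to reach the limit of the assay. Compound 3, like compound 1, is recorded only as a limit, so the step between these two cannot be read: the limit of > 100000 nM in this assay, at which 2 of the 3 values shown sit.

The compounds shown leave open whether this loss is tied to chlorine or would follow from any group in this place, such as fluoro, methyl or methoxy. They also do not tell whether a hydroxyl or an amine there, or chloro on another carbon of this ring, would give a measured number as compound 2 does.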